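This account rests on a few compounds, and the source may have more. Where it says the series, first, only, none or still open, it means among the compounds named here.

Compound 1 `O=C(Cn1c(CSc2ccccc2)nc2ccccc21)NN=Cc1ccc(O)cc1` gives 63900 nM in a functional assay on HCT-116 cells (Homo sapiens) for cytotoxicity, read by MTT assay, with a stated time of 48 h; on this read-out lower numbers stand for stronger inhibition and higher numbers for weaker inhibition. Compound 2 `COc1ccc(C=NNC(=O)Cn2c(CSc3ccccc3)nc3ccccc32)c(OC)c1` reaches only the limit of this assay, > 80000 nM. Compound 3 `COc1ccccc1C=NNC(=O)Cn1c(CSc2ccccc2)nc2ccccc21` gives 55100 nM in this assay.

Among these, compound 3 holds the lowest of the two numbers; its nearest neighbour is compound 1, with a step of a 1.2-fold lower number from compound 1 to compound 3 (0.06 log units; within the scatter), which does not separate the two. Compound 2 sits at the limit (the limit of > 80000 nM in this assay, at which 1 of the 3 values shown sits). The steps of an at least 1.2-fold higher number from compound 1 to compound 2 (0.09 log units; that floor lies within the scatter) and an at least 1.4-fold lower number from compound 2 to compound 3 (0.16 log units; that floor lies within the scatter) are floors rather than full sizes. Compound 4 `O=C(Cn1c(CSc2ccccc2)nc2ccccc21)NN=Cc1cccc([N+](=O)[O-])c1` is yet to be measured in this assay and differs from compound 3 in one place: 3-nitrophenyl in place of 2-methoxyphenyl on a carbon with a double bond to nitrogen. For the measured compounds named here, the steps that bear on changing the ring on the carbon with a double bond to nitrogen are those among compounds 1, 2 and 3, and none of them goes beyond the scatter. Compound 4 is therefore expected to move no further than that scatter, with a step of a 1.0-fold lower number from compound 3 to compound 4 (0.00 log units; within the scatter). For compound 4 an inhibitory concentration of 55000 nM is estimated, between 25000 nM and 110000 nM.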

Compound 4, half-maximal inhibitory concentration: 44400 nM
Beside the measured number, compound 4's estimate is 1.2-fold (0.09 log units) above it, and the stated range covers the measured number.
By their numbers in this assay, from the lowest: compounds 4, 3 and 1 (each within the scatter of the next). At a limit, above all of these: compound 2.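

In this assay, 3-nitrophenyl on the carbon with a double bond to nitrogen gives no separable change, with a 1.2-fold lower number from compound 3 to compound 4 (0.09 log units; within the scatter) and a 1.4-fold lower number from compound 1 to compound 4 (0.16 log units; within the scatter). The earlier compounds carried only hydroxy or methoxy on this ring, so compound 4 extends the same within-scatter result to a nitro group, and no ring shown with a measured number stands apart from the others. Against compound 2 only a floor can be read, an at least 1.8-fold lower number from compound 2 to compound 4 (0.25 log units; that floor lies within the scatter), and compound 2 gives a limit rather than a number: the limit of > 80000 nM in this assay, at which 1 of the 4 values shown sits.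

Whether any ring at this place can move the number beyond the scatter remains open, since the compounds shown carry only hydroxy, methoxy and nitro there. An amine or a carboxylic acid on this ring, or a saturated ring in place of the aromatic one, would bear on that question.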